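This account rests on a few compounds, and the source may have more. Where it says the series, first, only, none or still open, it means among the compounds named here.

Compound 1 `COc1ccc(C[C@H]2COC(=O)[C@@H]2Cc2ccc(OCC(=O)N3CCCCC3)c(OC)c2)cc1OC`: 293000 nM
Compound 2 `COc1ccc(C[C@H]2COC(=O)[C@@H]2Cc2ccc(OCc3cn(Cc4ccc(F)cc4)nn3)c(OC)c2)cc1OC`: 198000 nM

In an ADME assay on HeLa cells (Homo sapiens) for cytotoxicity, read by MTT assay (on this read-out lower numbers stand for stronger inhibition and higher numbers for weaker inhibition), compound 2 gives 198000 nM, and compound 1 gives 293000 nM; the two numbers sit within the usual scatter of each other, so neither stands apart. Compound 3 `COc1ccc(C[C@H]2COC(=O)[C@@H]2Cc2ccc(OCc3cn(Cc4ccccc4)nn3)c(OC)c2)cc1OC` differs from compound 2 by hydrogen in place of fluoro on an aromatic carbon. Going by the values given here, no step between measured compounds exists to gauge such a change, and the two values at hand offer no further guide. The expectation is therefore a step of no size beyond the scatter, a 1.1-fold higher number from compound 2 to compound 3 (0.05 log units; within the scatter). Compound 3 is expected to give 220000 nM, in the range 110000 nM to 440000 nM.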

Compound 3, half-maximal inhibitory concentration: 346000 nM
For compound 3 the middle estimate is 1.6-fold (0.20 log units) below the measured one; low and high end bracket the measured number.
By their numbers in this assay, from the lowest: compounds 2, 1 and 3 (each within the scatter of the next).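

In this assay, hydrogen in place of fluoro on an aromatic carbon, para to a large group, gives a 1.7-fold higher number from compound 2 to compound 3 (0.24 log units; within the scatter), so this first reading of the position shows no separation between the two groups. Likewise, 1-benzyl-1H-1,2,3-triazol-4-yl in place of (piperidin-1-yl)carbonyl gives a 1.2-fold higher number from compound 1 to compound 3 (0.07 log units; within the scatter). No measurement at hand bears on a cause for either step. The compounds shown leave open whether chloro, methoxy or an amine on that aromatic carbon would reach beyond the scatter. They also leave open what a longer chain in place of the benzyl group would give.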